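Swapping a methyl for 4-methylphenyl on a carbonyl carbon

This account rests on a few compounds, and the source may have more. Where it says the series, first, only, none or still open, it means among the compounds named here.

Compound 1 `CN1CCC(=O)/C(=C/c2ccc(OC3CCCC3)cc2)C1` gives 18100 nM
Compound 2 `CC(=O)/C=C/c1ccc(OC2CCCC2)cc1` gives 40900 nM
Compound 3 `O=C1CCC/C1=C\c1ccc(OC2CCCC2)cc1` gives > 100000 nM (a limit)

In a functional assay on MCF7 cells (Homo sapiens) for antiproliferative activity, read by MTT assay (a lower number here means a stronger inhibitor, a higher number a weaker inhibitor), only compound 1 and compound 2 return true numbers. Compound 2 has the higher of the two, and the gap to compound 1 lies beyond the usual scatter. For compound 3 the result is a limit of the assay, not a number.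

Compound 4 `Cc1ccc(C(=O)/C=C/c2ccc(OC3CCCC3)cc2)cc1` differs from compound 2 in one place: it carries 4-methylphenyl in place of methyl on a carbonyl carbon as the whole change. For the measured compounds named here, no measured pair shows this swap, so the expectation rests on little. Compound 2 at 40900 nM and compound 1 at 18100 nM are only a small step apart, which favours a modest move over a large one, although compound 3 goes against that. A modest step to a lower number in this assay is expected. As an estimate, the expected change is a 2.6-fold lower number from compound 2 to compound 4 (0.41 log units; beyond the scatter) in size and direction. Compound 4 is expected at 16000 nM with an estimated range from 5000 nM to 50000 nM for now.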

Compound 4, half-maximal inhibitory concentration: 36400 nM
For compound 4 the middle estimate is 2.3-fold (0.36 log units) below the measured one, and the stated range covers the measured number.
By their numbers in this assay, from the lowest: compounds 1, 4 and 2 (each within the scatter of the next, the first and the last beyond it). At a limit, above all of these: compound 3.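

In this assay, 4-methylphenyl in place of methyl on a carbonyl carbon gives a 1.1-fold lower number from compound 2 to compound 4 (0.05 log units; within the scatter), so the two compounds cannot be told apart. For the compounds shown here, this pair is the first to show that this carbonyl carbon can carry a much larger group, one with an aromatic ring, in place of a lone methyl without a step beyond the scatter, and equally that the added ring brings no clear gain. Compound 3 remains at a limit of the assay, not a number: the limit of > 100000 nM in this assay, at which 1 of the 4 values shown sits.

One pair cannot show whether this tolerance holds for other groups on that carbon. A phenyl ring carrying an amine or a carboxylic acid in place of 4-methylphenyl, or a longer chain in place of methyl, remains an open case in the compounds shown.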